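The compounds below may be only part of what the source reports. "The series", "measured", "known", "first", "only" and "open" are said of these compounds alone.

Measured compounds:
compound 1, `Nc1sc(-c2ccc(Cl)cc2)c(-c2ccc(Cl)cc2)c1C(=O)N1CCCC1` — 6220 nM in a functional assay on PC-3 cells (Homo sapiens) for inhibition, read by sulforhodamine B assay, with a stated time of 72 h; on this read-out higher numbers stand for weaker inhibition and lower numbers for stronger inhibition
compound 2, `Nc1sc(-c2ccc(Cl)cc2)c(-c2ccc(Cl)cc2)c1C(=O)NCc1ccccc1` — 31800 nM in this assay

Compound 1 holds the lower of the two numbers in this assay. Its one neighbour is compound 2, and the step of a 5.1-fold higher number from compound 1 to compound 2 (0.71 log units; beyond the scatter) lies beyond the scatter, so compound 1 is the stronger inhibitor of the pair shown. Compound 3, `Nc1sc(-c2ccc(Cl)cc2)c(-c2ccc(Cl)cc2)c1C(=O)NC1CC1`, has not yet been measured. It differs from compound 1 in a single place: cyclopropylamino in place of pyrrolidin-1-yl on a carbonyl carbon. Among the measured compounds shown here, only one measured step bears on this change, the one from compound 1 to compound 2, which likewise removes the pyrrolidin-1-yl group from the carbonyl carbon and puts a secondary amine with one hydrogen-bond donor in its place; that step was a 5.1-fold higher number from compound 1 to compound 2 (0.71 log units; beyond the scatter). For the measured compounds named here, the cyclopropylamino group is smaller than benzylamino, so the account expects a higher number for compound 3 than for compound 1, but a step of smaller size than the one to compound 2. Compound 3 is therefore estimated at 12000 nM in this assay, within a range of 4000 nM to 40000 nM. This corresponds to an expected step of a 1.9-fold higher number from compound 1 to compound 3 (0.29 log units; within the scatter).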

Compound 3, half-maximal inhibitory concentration: 3680 nM
Estimate against measurement, compound 3: 3.3-fold (0.51 log units) above, outside the stated range (below it).
By their numbers in this assay, from the lowest: compounds 3 and 1 (each within the scatter of the next); then compound 2.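

In this assay, the step of a 1.7-fold lower number from compound 1 to compound 3 (0.23 log units; within the scatter) lies within the scatter, so the change from pyrrolidin-1-yl to cyclopropylamino on the carbonyl carbon separates neither compound from the other, even though the entering group brings the amide hydrogen that pyrrolidin-1-yl lacks. Having that hydrogen therefore does not by itself go with the weaker result seen for compound 2, since compound 3 carries it too, and the step of an 8.6-fold lower number from compound 2 to compound 3 (0.94 log units; beyond the scatter) lies beyond the scatter with only cyclopropyl in place of benzyl on the amide-type nitrogen. The earlier pair could not separate these two readings, whereas the new compound ties the larger loss in this small set to the benzyl group rather than to the presence of the amide hydrogen, and no available evidence gives a reason for either step.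

As far as these compounds go, it remains open how a plain primary carboxamide, a straight ethyl or butyl chain on the amide nitrogen, or a morpholine in place of pyrrolidin-1-yl would read in this assay. From the compounds shown here alone, it also remains open whether a benzyl group with a substituent on its ring, or a phenethyl chain, would follow compound 2.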